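Clearance notes: isopropoxy to difluoromethoxy

This account rests on a few compounds, and the source may have more. Where it says the series, first, only, none or still open, it means among the compounds named here.

In an ADME assay on the whole organism (Mus musculus, strain CD-1) for pharmacokinetics (a higher number here means faster removal of the compound, a lower number slower removal), compound 1 (`CCOc1cc([C@](O)(CCN(C)C)[C@@H](c2cc3cc(Br)ccc3nc2OC)c2cccc(OC)c2F)cc(OC)n1`) gives 19 mL/min/kg and compound 2 (`COc1cc([C@](O)(CCN(C)C)[C@@H](c2cc3cc(Br)ccc3nc2OC)c2ccnc(OC)c2OC)cc(OC(C)C)n1`) gives 6.8 mL/min/kg as the lower of the two numbers. That gap lies beyond the scatter, so compound 2 is the slower-cleared of the pair.

Compound 3 (`COc1cc([C@](O)(CCN(C)C)[C@@H](c2cc3cc(Br)ccc3nc2OC)c2ccnc(OC)c2OC)cc(OC(F)F)n1`) has difluoromethyl in place of isopropyl on an oxygen on an aromatic ring and so reads as isopropoxy to difluoromethoxy.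

Among the compounds with values here, no two measured compounds differ in one place only, so the series gives no measured size for this change. No step beyond the scatter is expected in this assay for this replacement. The expected change is a 1.2-fold higher number from compound 2 to compound 3 (0.07 log units; within the scatter) and stays within the scatter. Compound 3 is estimated at 8 mL/min/kg with an expected range from 3.5 mL/min/kg to 18 mL/min/kg in this assay.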

Compound 3, clearance: 8.7 mL/min/kg
Compound 3: middle estimate off by 1.1-fold (0.04 log units), on the low side, and the stated range covers the measured number.
By their numbers in this assay, from the lowest: compounds 2 and 3 (each within the scatter of the next); then compound 1.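

Notes on the oxygen on an aromatic ring: in this assay, difluoromethyl in place of isopropyl gives a 1.3-fold higher number from compound 2 to compound 3 (0.11 log units; within the scatter) and is the first step in the series that can be read at a single place. With the rest of compound 2 held fixed, clearance does not separate these two groups at this position, although the three carbons of isopropyl give way to one carbon and two fluorines. No measurement at hand explains this reading.

As far as these compounds go, whether trifluoromethyl, cyclopropyl or a longer chain on this oxygen would read the same stays open. Also open, from the compounds shown here alone, is whether the same replacement would give a step of similar size on the core of compound 1, since one step on one core cannot show how far this reading carries.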